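This account rests on a few compounds, and the source may have more. Where it says the series, first, only, none or still open, it means among the compounds named here.

Compound 1 `Nc1ccccc1NC(=O)c1ccc(CSC(=S)N2CCN(c3ccc(F)cc3)CC2)cc1` gives 60.8% in a functional assay on HeLa cells (Homo sapiens) for antiproliferative activity, read by CCK-8 assay, with a stated time of 72 h, tested at 2 uM (a lower number here means a weaker effect, a higher number a stronger effect of the compound at the concentration tested), the higher of the two numbers obtained. Compound 2 `CC1CCCCN1C(=S)SCc1ccc(C(=O)Nc2ccccc2N)cc1` shows 45.5% in this assay, a number lower than that of compound 1 by more than the usual scatter. Compound 3 `Nc1ccccc1NC(=O)c1ccc(CSC(=S)N2CCN(c3ccncc3)CC2)cc1` differs from compound 1 by pyridin-4-yl in place of 4-fluorophenyl on an amine nitrogen in a ring. Going by the values given here, no measured pair isolates this change, so the expected step from compound 1 to compound 3 is small and is estimated to fall within the usual scatter, as a number 5.8 percentage points lower from compound 1 to compound 3 (within the scatter). Compound 3 is therefore expected to give about 55%, in the range 35% to 75%.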

Compound 3, a percentage reported as inhibition, at one concentration (the size of the read-out at that concentration, not a potency): 77%
Compound 3: the middle estimate sits 22 percentage points below what was measured; measured number outside the range, above it.
By their numbers in this assay, from the lowest: compound 2; then compound 1; then compound 3.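

Pyridin-4-yl in place of 4-fluorophenyl on this amine nitrogen in a ring gives a number 16.2 percentage points higher from compound 1 to compound 3 (beyond the scatter) in this assay. Going by these compounds alone, this shows that the read-out at this place responds to the identity of the aromatic ring, which no earlier pair could isolate. Nothing available explains the step.

From the compounds shown here alone, whether a plain phenyl, pyridin-3-yl or pyridin-2-yl at this place would give a similar number remains open. So does whether the ring nitrogen's location within pyridin-4-yl matters to the step at all.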